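A few compounds are considered here, and "the series" means these few. Any claim that something is new, unique, unknown or untested is made for them only; others in the source may bear on it.

Measured compounds:
compound 1 `Cc1ccc(NS(=O)(=O)c2ccc(-c3ccccc3)cc2)cc1Nc1nccc(-c2cccnc2)n1`, 8000 nM
compound 2 `COc1cc(-c2ccnc(Nc3cc(NS(=O)(=O)c4ccc(-c5ccccc5)cc4)ccc3C)n2)cc(OC)c1OC`, 6930 nM

Among the measured compounds shown here, in a functional assay on MDA-MB-231 cells (Homo sapiens) for cytotoxicity, read by MTT assay, with a stated time of 24 h (on this read-out higher numbers stand for weaker inhibition and lower numbers for stronger inhibition), compound 1 gives 8000 nM and compound 2 gives 6930 nM; the only step, a 1.2-fold lower number from compound 1 to compound 2 (0.06 log units; within the scatter), leaves compound 2 level with compound 1 within the scatter. Compound 3 `COc1ccc(S(=O)(=O)Nc2ccc(C)c(Nc3nccc(-c4cc(OC)c(OC)c(OC)c4)n3)c2)cc1OC` differs from compound 2 by 3,4-dimethoxyphenyl in place of 4-phenylphenyl on a sulfonyl sulfur. For the measured compounds named here, no measured step touches the group on the sulfonyl sulfur, so nothing seen so far bears on this change; the one step known concerns a different part of the molecule. With no guide, the expected step is a 1.2-fold higher number from compound 2 to compound 3 (0.06 log units; within the scatter), and the uncertainty is wide. Compound 3 is estimated at 8000 nM, between 3000 nM and 25000 nM.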

Compound 3, half-maximal inhibitory concentration: 7480 nM
Compound 3: the middle estimate sits 1.1-fold (0.03 log units) above what was measured; the measured number falls inside the stated range.
By their numbers in this assay, from the lowest: compounds 2, 3 and 1 (each within the scatter of the next).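

In this assay the exchange of 4-phenylphenyl for 3,4-dimethoxyphenyl on the sulfonyl sulfur gives a 1.1-fold higher number from compound 2 to compound 3 (0.03 log units; within the scatter) and so leaves the two compounds level. At this position, then, going from two aromatic rings to one and adding two hydrogen-bond acceptors does not shift the number beyond the scatter. No accompanying measurement offers an explanation for this result.

Going by these compounds, both groups compared here on the sulfonyl sulfur are aromatic, so the effect of a simple methyl group, a longer alkyl chain or an amine-bearing chain there remains open. Whether any group at this position can move the number beyond the scatter is also unknown.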